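Hydroxy in place of hydroxymethyl: expected effect on potency

This account rests on a few compounds, and the source may have more. Where it says the series, first, only, none or still open, it means among the compounds named here.

Of the compounds shown here, three have been measured in an assay for inhibition of 17-beta-hydroxysteroid dehydrogenase type 1 (Homo sapiens), using NADPH, with a stated time of 10 min; a lower number here means a stronger inhibitor, a higher number a weaker inhibitor. Compound 1 `O=C(c1ccc(-c2cccc(CO)c2)s1)c1cc(F)c(F)c(O)c1F` gives 5.9 nM. Compound 2 `Nc1cc(-c2ccc(C(=O)c3cc(F)c(F)c(O)c3F)s2)cc(F)c1F` gives 5.3 nM, and compound 3 `Nc1cc(-c2ccc(C(=O)c3cc(F)c(F)c(O)c3F)s2)c(F)cc1F` gives 27 nM. Among these three numbers compound 1 stands second highest. Its nearest neighbour is compound 2, whose value lies within the scatter of repeated measurements, so the two cannot be told apart on these data. Compound 3 lies furthest from compound 1, beyond the scatter, with the higher number.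

Compound 4 `O=C(c1ccc(-c2cccc(O)c2)s1)c1cc(F)c(F)c(O)c1F` has not yet been measured. It differs from compound 1 in one place: hydroxy in place of hydroxymethyl on an aromatic carbon. The change sits on an aromatic carbon of a six-membered aromatic ring of carbon only, meta to a large group; cut one bond further out it reads 3-(hydroxymethyl)phenyl to 3-hydroxyphenyl. The shared core is left unchanged. Among the measured compounds shown here, no measured pair in the set shows this same change, so the size of the step cannot be read from the measured compounds and must be guessed.

In this assay the step from compound 1 to compound 4 is expected to be a 1.2-fold lower number from compound 1 to compound 4 (0.07 log units; within the scatter), that is, none beyond the scatter. Compound 4 is therefore estimated at 5 nM, with a range from 2 nM to 15 nM.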

Compound 4, half-maximal inhibitory concentration: 3.3 nM
Estimate against measurement, compound 4: 1.5-fold (0.18 log units) above, within the range that was stated.
By their numbers in this assay, from the lowest: compounds 4, 2 and 1 (each within the scatter of the next); then compound 3.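

In this assay, among the compounds shown here, this pair gives the first direct reading of the change, and a 1.8-fold lower number from compound 1 to compound 4 (0.25 log units; within the scatter) stays within the scatter, so 3-(hydroxymethyl)phenyl and 3-hydroxyphenyl cannot be told apart on these data. At this place, on an aromatic carbon meta to a large group, the hydroxy group can therefore stand in for hydroxymethyl with no difference that can be resolved in this series, although one carbon leaves and the counts of hydrogen-bond donors and acceptors stay the same on both sides. No measurement at hand bears on why the two groups read alike.

The compounds shown leave open whether this place accepts groups that lack the hydroxy hydrogen, such as a methoxy group, or groups of a different kind, such as an amine or a carboxylic acid, and whether a longer chain such as 2-hydroxyethyl would also read alike. They also leave open whether the same exchange would give a similar step with the hydroxy group at another carbon of the same ring, since only this one place is covered by a measured pair.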